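Bromo for methyl on the aryl ring: compound 4

The source may hold more compounds than are shown below. What is called first, only, known or untested is meant among the compounds shown, and "the series" means these compounds.

Going by the values given here, the three measured members share one core and differ in the aryl group attached to it. Compound 1 `Cc1ccc(Nc2nc(SCc3cn(CC(=O)NC(=O)Nc4ccccn4)nn3)nc(-c3ccc(C(C)C)cc3)c2C#N)cc1` gives 3060 nM in a functional assay on B16-F10 cells (Mus musculus) for inhibition, read by MTT assay, with a stated time of 72 h; a higher number here means a weaker inhibitor, a lower number a stronger inhibitor. Compound 2 `COc1cc(-c2nc(SCc3cn(CC(=O)NC(=O)Nc4ccccn4)nn3)nc(Nc3ccc(C)cc3)c2C#N)cc(OC)c1OC` gives 32 nM, and compound 3 `Cc1ccc(Nc2nc(SCc3cn(CC(=O)NC(=O)Nc4ccccn4)nn3)nc(-c3ccc(C)cc3)c2C#N)cc1` gives 1010 nM. Compound 3 thus stands second highest of the three numbers: its nearest neighbour is compound 1, separated by a 3.0-fold lower number from compound 1 to compound 3 (0.48 log units; beyond the scatter), while the step of a 32-fold higher number from compound 2 to compound 3 (1.50 log units; beyond the scatter) sets it far from compound 2, the strongest inhibitor of the set. The related step of a 96-fold lower number from compound 1 to compound 2 (1.98 log units; beyond the scatter) is likewise large.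

Compound 4 `Cc1ccc(Nc2nc(SCc3cn(CC(=O)NC(=O)Nc4ccccn4)nn3)nc(-c3ccc(Br)cc3)c2C#N)cc1` is not yet measured. It differs from compound 3 by bromo in place of methyl on an aromatic carbon. Among the compounds with values here, the only measured step at this position is a 3.0-fold lower number from compound 1 to compound 3 (0.48 log units; beyond the scatter), a modest one; the two large steps each exchange the whole aryl group and bring in or remove a 3,4,5-trimethoxyphenyl, which plays no part here. Within the data shown here, no measured step involves bromo. A modest step in either direction, or none beyond the scatter, is therefore expected for compound 4, a 1.1-fold lower number from compound 3 to compound 4 (0.05 log units; within the scatter). Compound 4 is estimated at 900 nM, within a range from 300 nM to 3000 nM.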

Compound 4, half-maximal inhibitory concentration: 8160 nM
Beside the measured number, compound 4's estimate is 9.1-fold (0.96 log units) below it; measured number outside the range, above it.
By their numbers in this assay, from the lowest: compound 2; then compound 3; then compound 1; then compound 4.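

Para to a large group on the aryl ring, bromo in place of methyl gives an 8.1-fold higher number from compound 3 to compound 4 (0.91 log units; beyond the scatter) in this assay, so a one-atom exchange at this position moves the number well beyond the scatter. Bromo also ranks above isopropyl, with a 2.7-fold higher number from compound 1 to compound 4 (0.43 log units; beyond the scatter), which sets the order at this position, from the lowest number, as methyl, isopropyl, bromo, while the exchange of the whole aryl group gives a 260-fold higher number from compound 2 to compound 4 (2.41 log units; beyond the scatter) and leaves compound 4 the weakest inhibitor of the four. Nothing at hand explains why bromo stands above both alkyl groups.

From the compounds shown here alone, whether a 4-chlorophenyl or 4-aminophenyl group would follow bromo or methyl remains open. So does whether bromo would raise the number to the same extent on a ring that also carries methoxy groups.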